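The source may hold more compounds than are shown below. What is called first, only, known or untested is meant among the compounds shown, and "the series" means these compounds.

Compound 2 `N#CC1=C(N)Oc2c(N)cc3nc4ccccc4nc3c2C12C(=O)N(Cc1cnnn1-c1cccc(Br)c1)c1ccccc12` carries a 3-bromophenyl group on an aromatic nitrogen of the shared core. In a functional assay on HepG2 cells (Homo sapiens) for antiproliferative activity, read by MTT assay, with a stated time of 48 h (a higher number here means a weaker inhibitor, a lower number a stronger inhibitor), compound 2 gives only a limit, > 50000 nM. Compound 1 `CCc1ccccc1-n1nncc1CN1C(=O)C2(C(C#N)=C(N)Oc3c(N)cc4nc5ccccc5nc4c32)c2ccccc21`, which bears a 2-ethylphenyl group at the same place, gives in this assay a measured number, 17900 nM. The step of an at least 2.7-fold higher number from compound 1 to compound 2 (0.44 log units; beyond the scatter) therefore went toward weaker inhibition, and its true size is known only as a lower bound because of the limit of > 50000 nM in this assay, at which 1 of the 2 values shown sits. Compound 3 `CCOc1ccc(-n2nncc2CN2C(=O)C3(C(C#N)=C(N)Oc4c(N)cc5nc6ccccc6nc5c43)c3ccccc32)cc1` has not yet been measured; it differs from compound 2 by 4-ethoxyphenyl in place of 3-bromophenyl on an aromatic nitrogen. For the measured compounds named here, only that one measured step bears on this change, and it shows that exchanging the group on this nitrogen can shift the number beyond the scatter. Going by the values given here, no measured step involves a 4-ethoxyphenyl group, so the direction remains open. Compound 3 is expected at 40000 nM, within 12000 nM to 150000 nM. That estimate means an expected step of an at least 1.2-fold lower number from compound 2 to compound 3 (0.09 log units; that floor lies within the scatter).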

Compound 3, half-maximal inhibitory concentration: > 50000 nM
Compound 3: no number, only a limit; the forecaster's own chance of this, stated with the estimate: 45%; at least 1.2-fold (0.09 log units) between middle value and limit.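

With 4-ethoxyphenyl on this aromatic nitrogen, compound 3 also gives only a limit in this assay, and the comparison with the measured compound shows an at least 2.7-fold higher number from compound 1 to compound 3 (0.44 log units; beyond the scatter). A second, different group thus moves the result the same way as 3-bromophenyl did, so among the three groups shown, only 2-ethylphenyl gives a measured number. The step between the two compounds that end at a limit cannot be read, so nothing ranks 3-bromophenyl against 4-ethoxyphenyl: the limit of > 50000 nM in this assay, at which 2 of the 3 values shown sit.

The compounds shown leave open how an unsubstituted phenyl, or a phenyl carrying an amine or a carboxylic acid, would behave on this nitrogen. They also leave open whether any group here could give a lower number than compound 1 does.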